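Replacing the chlorothiophene with a benzothiophene

A few compounds are considered here, and "the series" means these few. Any claim that something is new, unique, unknown or untested is made for them only; others in the source may bear on it.

Of the compounds shown here, three sharing one core have been tested in a functional assay on Jurkat cells for inhibition of nuclear factor NF-kappa-B complex (Homo sapiens); on this read-out higher numbers stand for weaker inhibition and lower numbers for stronger inhibition. Compound 1, `CCOC(=O)c1cnc(-n2nc(C)cc2C)nc1NN1C(=O)C=C(C)C1=O`, gives 10000 nM. Compound 2, `CCOC(=O)c1cnc(-c2ccc(F)cc2)nc1NN1C(=O)C=C(C)C1=O`, gives 700 nM. Compound 3, `CCOC(=O)c1cnc(-c2ccc(Cl)s2)nc1NN1C(=O)C=C(C)C1=O`, gives 300 nM, the lowest of the three numbers, with compound 2 nearest and compound 1 furthest away. The measured steps all concern the group attached at the same position on the core: a 14-fold lower number from compound 1 to compound 2 (1.15 log units; beyond the scatter), a 33-fold lower number from compound 1 to compound 3 (1.52 log units; beyond the scatter), and a 2.3-fold lower number from compound 2 to compound 3 (0.37 log units; beyond the scatter).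

Compound 4, `CCOC(=O)c1cnc(-c2cc3ccccc3s2)nc1NN1C(=O)C=C(C)C1=O`, has not yet been measured. It differs from compound 3 in one place: 1-benzothiophen-2-yl in place of 5-chlorothiophen-2-yl on an aromatic carbon. Both the leaving and the entering group are aromatic and carry a sulfur, so the relevant measured steps are those between the aromatic groups, above all the modest step from compound 2 to compound 3. Nothing measured here shows how a fused six-membered ring at this position changes the read-out, so the direction is open. Compound 4 is therefore expected to stay close to compound 3, with a step of no change at the digits printed from compound 3 to compound 4 (within the scatter) in this assay that may well lie within the scatter. The estimate for compound 4 in this assay is 300 nM, with a range from 100 nM to 1000 nM.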

Compound 4, half-maximal inhibitory concentration: 4000 nM
For compound 4 the middle estimate is 13-fold (1.12 log units) below the measured one; measured number outside the range, above it.
By their numbers in this assay, from the lowest: compound 3; then compound 2; then compound 4; then compound 1.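

Swapping 5-chlorothiophen-2-yl for 1-benzothiophen-2-yl at this position gives a 13-fold higher number from compound 3 to compound 4 (1.12 log units; beyond the scatter) in this assay, so two aromatic groups that each carry a sulfur and a five-membered aromatic ring are far from interchangeable here. The new group also falls behind 4-fluorophenyl, with a 5.7-fold higher number from compound 2 to compound 4 (0.76 log units; beyond the scatter), and it keeps only a small part of the gain over 3,5-dimethyl-1H-pyrazol-1-yl, with a 2.5-fold lower number from compound 1 to compound 4 (0.40 log units; beyond the scatter), which shows that an aromatic group with sulfur at this position does not by itself give strong inhibition. No supporting measurement is available to explain why this change has such a large effect on the read-out.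

The change removes the chlorine and adds a six-membered carbon ring at the same time, so these compounds cannot show which of the two matters more; a plain thiophen-2-yl group, with neither the chlorine nor the extra ring, would help separate them. From the compounds shown here alone, it also remains open how this position responds to a non-aromatic group, such as a morpholine ring or a short amine chain, in place of these aromatic rings.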